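The source may report more compounds than this note shows. Statements on the series, on what has been measured and on what is new or still open speak of the compounds shown alone.

Compound 1 `Cc1ccc(CS/C(=C/c2cc(C)ccc2C)C(=O)c2ccc(Cl)cc2)cc1` and compound 2 `Cc1ccc(CS/C(=C/c2ccccc2F)C(=O)c2ccc(Cl)cc2)cc1` share a core and differ in one place: 2-fluorophenyl in place of 2,5-dimethylphenyl on a double-bonded chain carbon bound to a double-bonded chain carbon. In a functional assay on DU-145 cells (Homo sapiens) for inhibition, read by trypan blue exclusion, with a stated time of 96 h (a lower number here means a stronger inhibitor of growth, a higher number a weaker inhibitor of growth), compound 1 gives 10000 nM, and compound 2 gives 10000 nM, so that no change at the digits printed from compound 1 to compound 2 (within the scatter). Compound 3 `Cc1ccc(C)c(/C=C(\C(=O)c2ccc(Cl)cc2)S(=O)(=O)c2ccc(Br)cc2)c1` is built on a different core, and the difference between the two cores is not broken down here. In this assay compound 3 gives 1000 nM, the lowest of the three numbers, and its gap to compound 1 as well as to compound 2 lies beyond the scatter. Compound 4 `O=C(/C(=C\c1ccccc1F)S(=O)(=O)c1ccc(Br)cc1)c1ccc(Cl)cc1` has not yet been measured in this assay. It stands to compound 3 as compound 2 stands to compound 1, with the same change at the same place: 2-fluorophenyl in place of 2,5-dimethylphenyl on a double-bonded chain carbon bound to a double-bonded chain carbon. The step is expected to be no change at the digits printed from compound 3 to compound 4 (within the scatter), close to the earlier one, because the same change gave no change at the digits printed from compound 1 to compound 2 (within the scatter). Compound 4 is therefore expected to give 1000 nM in this assay, with a likely range from 400 nM to 2500 nM, the measurement of which is still to come.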

Compound 4, concentration for 50% growth inhibition: 25000 nM
Estimate against measurement, compound 4: 25-fold (1.40 log units) below, and the stated range ends below it.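

In this assay, the replacement of 2,5-dimethylphenyl by 2-fluorophenyl leaves the number unchanged on one core, no change at the digits printed from compound 1 to compound 2 (within the scatter), but on the other it gives a 25-fold higher number from compound 3 to compound 4 (1.40 log units; beyond the scatter). The change therefore did not carry over from the core of compound 1 to the core of compound 3, and the two steps differ: the same change on two cores in this assay, no change at the digits printed (within the scatter) from compound 1 to compound 2 and a 25-fold higher number (1.40 log units; beyond the scatter) from compound 3 to compound 4, 25-fold (1.40 log units) apart, beyond the scatter of two such steps This shows that, among these four compounds, the outcome of the change is tied to the core that carries it, but with only one pair on each core it does not show which part of the difference between the cores is responsible, nor how the result arises.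

The compounds shown leave open how other groups at this place would behave on each core, for example a phenyl ring carrying an amine or a carboxylic acid in place of the 2-fluorophenyl. They also leave open whether the gap between the two steps would persist with a longer chain on the double-bonded chain carbon.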